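The source may report more compounds than this note shows. Statements on the series, on what has been measured and on what is new or still open speak of the compounds shown alone.

Working notes on the series.

Within the data shown here, compound 1, with structure `C/C=C1/[C@H](O[C@@H]2O[C@H](CO)[C@@H](O)[C@H](O)[C@H]2O)OC=C(C(=O)OC)[C@H]1CC(=O)OCCc1ccc(O)c(O)c1`, is the only member of the set with a full number in a functional assay on SK-BR-3 cells (Homo sapiens) for antiproliferative activity, read by MTT assay, with a stated time of 72 h; a higher number here means a weaker inhibitor, a lower number a stronger inhibitor: in this assay compound 1 gives 160000 nM. Compound 2, with structure `C=CCOC(=O)C[C@@H]1C(C(=O)OC)=CO[C@@H](O[C@@H]2O[C@H](COC(C)=O)[C@@H](OC(C)=O)[C@H](OC(C)=O)[C@H]2OC(C)=O)/C1=C/C`, carries a peracetylated sugar and an allyl ester in place of the catechol-bearing ester of compound 1. For compound 2 this assay reports only a limit, > 20000 nM, and not a number. The remaining datum is the limit of > 20000 nM in this assay, at which 1 of the 2 values shown sits, so compound 1 cannot be ranked against compound 2 beyond noting that its value is the one measured figure.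

Compound 3, with structure `C/C=C1/[C@H](O[C@@H]2O[C@H](CO)[C@@H](O)[C@H](O)[C@H]2O)OC=C(C(=O)OC)[C@H]1CC(=O)OCCCc1ccc(OC)c(OC)c1`, keeps the free sugar and the core of compound 1 and differs only in the ester side chain, by 3,4-dimethoxybenzyl in place of 3,4-dihydroxyphenyl on a saturated chain carbon, two bonds along the chain from an oxygen next to a carbonyl group. Among the measured compounds shown here, no measured step between two compounds of the set shows what such a change does here. The step is expected to be modest, toward a stronger inhibitor, at roughly the edge of the usual scatter, as a 1.8-fold lower number from compound 1 to compound 3 (0.25 log units; within the scatter). Compound 3 is therefore estimated to give about 90000 nM, with a plausible range from 30000 nM to 300000 nM.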

Compound 3, half-maximal inhibitory concentration: > 20000 nM
Compound 3: only a limit was reported; the forecaster's own chance of this, stated with the estimate: 25%; the middle value is on the limit's open side.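

In this assay, among these compounds, compound 3 gives only a limit (> 20000 nM) and not a number, so no step from compound 1 to compound 3 can be read. Left open is how the ester side chain bears on activity in this assay when most values shown stand at one limit: the limit of > 20000 nM in this assay, at which 2 of the 3 values shown sit.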